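A few compounds are considered here, and "the series" means these few. Any claim that something is new, unique, unknown or untested is made for them only; others in the source may bear on it.

For the measured compounds named here, compound 3 `CN1CCN(c2ccc(Nc3ncc4nc(Nc5ccc(F)cc5)n([C@H]5CCCN(C(=O)CO)C5)c4n3)cc2)CC1` stands at the lowest of the three numbers measured so far: in a functional assay on HCC827 cells (Homo sapiens) for antiproliferative activity, read by MTT assay, with a stated time of 72 h (on this read-out lower numbers stand for stronger inhibition and higher numbers for weaker inhibition), compound 3 gives 1.8 nM. Its nearest neighbour is compound 2 `CN1CCN(c2ccc(Nc3ncc4nc(Nc5ccc(F)cc5)n([C@H]5CCCN(S(=O)(=O)C6CC6)C5)c4n3)cc2)CC1`, which in this assay gives 8.6 nM, a gap of a 4.8-fold lower number from compound 2 to compound 3 (0.68 log units; beyond the scatter). Furthest away is compound 1 `CN1CCN(c2ccc(Nc3ncc4nc(Nc5ccc(F)cc5)n([C@@H]5CCN(C(=O)CO)C5)c4n3)cc2)CC1`, which in this assay gives 350 nM, a gap of a 190-fold lower number from compound 1 to compound 3 (2.29 log units; beyond the scatter).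

Compound 4 `CN1CCN(c2ccc(Nc3ncc4nc(Nc5ccc(F)cc5)n(-c5cccc(NC(=O)CO)c5)c4n3)cc2)CC1` differs from compound 3 in one place: 3-(((hydroxymethyl)carbonyl)amino)phenyl in place of 1-((hydroxymethyl)carbonyl)piperidin-3-yl on an aromatic nitrogen. Going by the values given here, the two measured steps that touch this position, the ring-size change of a 190-fold lower number from compound 1 to compound 3 (2.29 log units; beyond the scatter) and the exchange of the group on the ring nitrogen of a 4.8-fold lower number from compound 2 to compound 3 (0.68 log units; beyond the scatter), show that this position moves the number strongly, but neither replaces the saturated ring by an aromatic one, so no measured step tests the change to compound 4 directly. The hydroxymethyl carbonyl group of compound 3 is kept, now as an anilide. Compound 4 is therefore expected to give a higher number, a step of an 8.3-fold higher number from compound 3 to compound 4 (0.92 log units; beyond the scatter) beyond the scatter. The estimate for compound 4 is 15 nM, with a range from 3 nM to 80 nM.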

Compound 4, half-maximal inhibitory concentration: 7.5 nM
Beside the measured number, compound 4's estimate is 2.0-fold (0.30 log units) above it; measured number inside the range.
By their numbers in this assay, from the lowest: compound 3; then compounds 4 and 2 (each within the scatter of the next); then compound 1.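

Read in this assay, the group on the aromatic nitrogen can be a six-membered aromatic ring of carbon only, and the change to 3-(((hydroxymethyl)carbonyl)amino)phenyl costs only a modest step (a 4.2-fold higher number from compound 3 to compound 4 (0.62 log units; beyond the scatter)). That group stands level with 1-(cyclopropylsulfonyl)piperidin-3-yl (a 1.1-fold lower number from compound 2 to compound 4 (0.06 log units; within the scatter)) and far from 1-((hydroxymethyl)carbonyl)pyrrolidin-3-yl (a 47-fold lower number from compound 1 to compound 4 (1.67 log units; beyond the scatter)), so among these compounds neither a non-aromatic ring nor a defined stereocentre is needed for a low number, though the lowest number still belongs to the piperidine of compound 3. Nothing at hand accounts for these steps.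

The compounds shown leave open how much of this rests on the (hydroxymethyl)carbonyl group of the anilide. A phenyl ring carrying a plain amine or a carboxylic acid at that place, or a longer chain on the carbonyl, could settle this.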